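Methyl to nitro on the shared core

A few compounds are considered here, and "the series" means these few. Any claim that something is new, unique, unknown or untested is made for them only; others in the source may bear on it.

Measured in a physicochemical assay for solubility; on this read-out higher numbers stand for higher solubility and lower numbers for lower solubility:
- compound 1 `COc1ccc(O)c(C(=O)Nc2ccc([N+](=O)[O-])cc2Cl)c1`: 2.1 ug/mL
- compound 2 `Cc1ccc(O)c(C(=O)Nc2ccc([N+](=O)[O-])cc2Cl)c1`: < 1 ug/mL

Compound 2 gives < 1 ug/mL, which is a limit of the assay and not a number. The next entry is compound 3 `O=C(Nc1ccc([N+](=O)[O-])cc1Cl)c1cc([N+](=O)[O-])ccc1O`, with nitro in place of methyl on an aromatic carbon, para to a hydroxy group (nitro in place of methyl on an aromatic carbon). Going by the values given here, the only measured step, an at least 2.1-fold lower number from compound 1 to compound 2 (0.32 log units; beyond the scatter), concerns methyl in place of methoxy on that carbon, so it bears only indirectly on nitro. A small upward step in this assay is expected, possibly none beyond the scatter: an at least 1.2-fold higher number from compound 2 to compound 3 (0.07 log units; that floor lies within the scatter). For compound 3 the estimate is 1.2 ug/mL, with an expected range of 0.5 ug/mL to 3.5 ug/mL.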

Compound 3, solubility: > 50 ug/mL
Compound 3 was reported as a limit; the forecaster's own chance of this, stated with the estimate: 45%; middle value at least 41-fold (1.61 log units) away from the limit.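

In this assay, the carbon para to a hydroxy group proves far more responsive than the methoxy-to-methyl comparison suggested, with nitro in place of methyl giving an at least 50-fold higher number from compound 2 to compound 3 (1.69 log units; beyond the scatter). Nitro in place of methoxy also gives a large change, an at least 23-fold higher number from compound 1 to compound 3 (1.37 log units; beyond the scatter), so the rise does not rest only on the comparison with compound 2. Compound 3 gives > 50 ug/mL, which is a limit of the assay and not a number.

As far as these compounds go, how far compound 3 lies past that limit remains open, and so does the full size of both steps. Also open, from the compounds shown here alone, is whether an amine or a carboxylic acid on this carbon would give a similar read-out.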